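The source may report more compounds than this note shows. Statements on the series, on what has been measured and on what is new or still open speak of the compounds shown alone.

In an assay on isolated protein for binding affinity to histamine H2 receptor (Homo sapiens) (on this read-out higher numbers stand for weaker inhibition and lower numbers for stronger inhibition), compound 1 `CC(=O)c1ccc(OCCCN2CC[C@H](NC(=O)c3ccc(C#N)cc3)C2)cc1` gives 6100 nM, and compound 2 `O=C(c1ccc(OCCCN2CC[C@H](NS(=O)(=O)c3ccc(Br)cc3)C2)cc1)C1CC1` gives 290 nM. Of these two numbers, compound 2 carries the lower one, and its distance to compound 1 lies well beyond the usual scatter of repeated measurements, so compound 2 is the stronger binder of the pair. Compound 3 `O=C(c1ccc(OCCCN2CC[C@H](NS(=O)(=O)c3ccccc3)C2)cc1)C1CC1` differs from compound 2 in a single place: hydrogen in place of bromo on an aromatic carbon, which reads, one bond further out, as (4-bromophenyl)sulfonyl becoming phenylsulfonyl. Going by the values given here, no step between two measured compounds shows what this particular change does in this assay, so the expectation rests on the change alone. A modest move toward a higher number, that is toward weaker binding, is expected, a 2.4-fold higher number from compound 2 to compound 3 (0.38 log units; beyond the scatter), without confidence that it clears the scatter. Compound 3 is therefore estimated at 700 nM, with a likely range from 250 nM to 2000 nM.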

Compound 3, inhibition constant: 1200 nM
Beside the measured number, compound 3's estimate is 1.7-fold (0.23 log units) below it; measured number inside the range.
By their numbers in this assay, from the lowest: compound 2; then compound 3; then compound 1.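

In this assay, going by these compounds alone, replacing bromo with hydrogen gives a 4.1-fold higher number from compound 2 to compound 3 (0.62 log units; beyond the scatter), the first step that isolates this position, since compound 1 differs from compound 2 in more than one place. A single bromine atom on an aromatic carbon, para to a large group, therefore separates the two compounds by more than the usual scatter, and compound 2, which carries the bromo, is the stronger binder of the pair. Nothing available gives a reason for this difference.

On these data alone, whether chloro, fluoro, methyl or methoxy on that same carbon would keep the number close to that of compound 2 remains open. As far as these compounds go, it is also open whether bromo on another carbon of the ring would give a step of similar size.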